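Phenoxy for isobutyl on a shared carbonyl

The source may report more compounds than this note shows. Statements on the series, on what has been measured and on what is new or still open speak of the compounds shown alone.

Measured compounds:
compound 1, `Cn1ncc([N+](=O)[O-])c1C(=O)Nc1ccc2nc(NC(=O)C3CCCCC3)sc2c1`, 0.026 ug/mL
compound 2, `O=C(Nc1ccc2nc(NC(=O)C3CCCCC3)sc2c1)c1cccc(Oc2ccccc2)c1`, > 4 ug/mL
compound 3, `CC(C)CC(=O)Nc1nc2ccc(NC(=O)c3c(Cl)cccc3Cl)cc2s1`, 0.012 ug/mL

In a functional assay on WI-38 VA13 cells (Homo sapiens) for cytotoxicity (on this read-out lower numbers stand for an effect already at smaller amounts and higher numbers for an effect only at larger amounts of compound), compound 3 has the lowest of the two numbers shown; its nearest neighbour is compound 1, whose number is higher by an amount beyond the scatter. The value given for compound 2 is a limit of this assay and not a number: the limit of > 4 ug/mL in this assay, at which 1 of the 3 values shown sits.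

Compound 4, `O=C(Nc1nc2ccc(NC(=O)c3c(Cl)cccc3Cl)cc2s1)Oc1ccccc1`, has not yet been measured in this assay. It differs from compound 3 in one place: phenoxy in place of isobutyl on a carbonyl carbon. The same difference, cut one bond further out, reads isobutylcarbonyl to phenoxycarbonyl, so an (isobutylcarbonyl)amino group becomes a (phenoxycarbonyl)amino group.

Among the compounds with values here, no measured pair shows a change at this place, so the size of the step can only be guessed. Compound 1 and compound 3 show that this part of the molecule tolerates some change while the numbers stay low. A small loss, of a size not far beyond the scatter, is expected for the step of a 2.5-fold higher number from compound 3 to compound 4 (0.40 log units; beyond the scatter). For compound 4 the expected value in this assay is 0.03 ug/mL, with a likely range from 0.008 ug/mL to 0.15 ug/mL.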

Compound 4, half-maximal effective concentration: 1.1 ug/mL
The estimate for compound 4 lay 37-fold (1.56 log units) below the measured number, outside the stated range (above it).
By their numbers in this assay, from the lowest: compound 3; then compound 1; then compound 4. At a limit, above all of these: compound 2.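

Within the data shown here, the exchange of isobutyl for phenoxy on the carbonyl carbon is the first change at this place that can be read on its own, and in this assay it gives a 92-fold higher number from compound 3 to compound 4 (1.96 log units; beyond the scatter) with the rest of the molecule unchanged. The earlier compounds shown here showed low numbers with different groups elsewhere in the molecule, but they could not show that this place, on a carbonyl carbon whose other neighbour is an amide-type nitrogen, is so sensitive to what it carries: a single change here moves the number by a large step. Nothing among the measurements shown explains why the step is this large.

The change brings in a six-membered aromatic ring and an oxygen together, so the compounds shown leave open which of the two goes with the higher number: a benzyl group would keep the ring without the oxygen, while an isobutoxy group would keep the oxygen without the ring. Also open, going by these compounds, is how a longer chain or an amine would fare at this carbonyl carbon.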